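The source may report more compounds than this note shows. Statements on the series, on what has been measured and on what is new or still open speak of the compounds shown alone.

Of the compounds shown here, three built on one shared core have been tested in a functional assay on A-375 cells (Homo sapiens) for antiproliferative activity, read by trypan blue exclusion, with a stated time of 48 h, tested at 10 uM; a lower number here means a stronger effect, a higher number a weaker effect of the compound at the concentration tested. Compound 1 `CC(=O)Nc1nc(-c2cccc(NS(=O)(=O)c3ccc(Br)cc3)c2)cs1` gives 25.6%, compound 2 `C#Cc1ccc(S(=O)(=O)Nc2cccc(-c3csc(NC(C)=O)n3)c2)cc1` gives 1.2%, and compound 3 `CC(=O)Nc1nc(-c2cccc(NS(=O)(=O)c3cccc(C#C[Si](C)(C)C)c3)c2)cs1` gives 5.8%. Going by the values given here, the one measured single-point step, a number 24.4 percentage points lower from compound 1 to compound 2 (beyond the scatter), shows a clear drop when an ethynyl group replaces bromo. Compound 3 stands second highest of the three numbers, within the scatter of compound 2 but well apart from compound 1. Compound 4 `C#Cc1cccc(S(=O)(=O)Nc2cccc(-c3csc(NC(C)=O)n3)c2)c1` differs from compound 3 by a hydrogen atom in place of a group of 4 heavy atoms (3 carbon, 1 silicon; no ring), on a triple-bonded carbon. Among the compounds with values here, no measured step covers this exact change; the closest guidance is that compound 2, which also carries a free ethynyl group, sits low. Compound 4 is therefore expected to show no step beyond the scatter, a number 1.8 percentage points lower from compound 3 to compound 4 (within the scatter). Compound 4 is estimated at 4%, within a range from 0.5% to 15%.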

Compound 4, a percentage reported as activity, at one concentration (the size of the read-out at that concentration, not a potency): 18.6%
Compound 4: middle estimate off by 14.6 percentage points, on the low side; the whole stated range lies below it.
By their numbers in this assay, from the lowest: compounds 2 and 3 (each within the scatter of the next); then compounds 4 and 1 (each within the scatter of the next).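

In this assay, a hydrogen atom in place of the group of 4 heavy atoms (3 carbon, 1 silicon) on the triple-bonded carbon gives a number 12.8 percentage points higher from compound 3 to compound 4 (beyond the scatter), so what sits on that carbon matters. A free ethynyl group alone does not ensure a low number: 3-ethynylphenyl in place of 4-ethynylphenyl gives a number 17.4 percentage points higher from compound 2 to compound 4 (beyond the scatter). 3-Ethynylphenyl in place of 4-bromophenyl gives a number 7 percentage points lower from compound 1 to compound 4 (within the scatter), so these two sulfonyl substituents are not told apart. No evidence at hand explains these steps. On these data alone, whether a methyl group or a longer carbon chain on the triple-bonded carbon would give a number nearer compound 3 or compound 4 stays open.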